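Notes on compound 4, a chain isomer of compound 2

This account rests on a few compounds, and the source may have more. Where it says the series, first, only, none or still open, it means among the compounds named here.

Measured so far:
compound 1, `C1=C(CCN2CCN(c3cccc4c3OCCO4)CC2)c2ccccc2CCC1` — in an assay for activation of Adrenergic receptor alpha-1 (Rattus norvegicus) (a lower number here means that less compound is needed, a higher number that more compound is needed for the effect), compound 1 gives only a limit, > 2.5 mg/kg
compound 2, `c1ccc2c(c1)CC(CCCN1CCN(c3cccc4c3OCCO4)CC1)C2` — compound 2 gives 1.73 mg/kg
compound 3, `C1=C(CCN2CCN(c3cccc4c3OCCO4)CC2)c2ccccc2C1` — compound 3 gives 0.3 mg/kg

Among the two numbers shown, compound 2 stands highest; compound 3 gives the lower number, and the gap between compound 3 and compound 2 is beyond the scatter. Compound 1 sits at a limit: the limit of > 2.5 mg/kg in this assay, at which 1 of the 3 values shown sits. Among the measured compounds shown here, no two of the measured compounds differ in a single place, so no measured step is available as a guide for the change considered here.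

Compound 4, `c1ccc2c(c1)CC2CCCCN1CCN(c2cccc3c2OCCO3)CC1`, has not been measured. It differs from compound 2 as follows: a group of 9 heavy atoms (9 carbon; one four-membered non-aromatic ring of carbon only, one six-membered aromatic ring of carbon only) in place of a group of 9 heavy atoms (9 carbon; one five-membered non-aromatic ring of carbon only, one six-membered aromatic ring of carbon only), on a saturated chain carbon, three bonds along the chain from an amine nitrogen in a ring. The two compounds hold the same atoms, joined differently; the saturated chain between the ring amine nitrogen and the bicyclic group is rearranged along with the ring fusion.

For the measured compounds named here, with no measured step of this kind, the expectation for the step in this assay rests on the value of compound 2 alone, 1.73 mg/kg, and is for a small move toward a higher number or none beyond the scatter. The step expected is a 1.4-fold higher number from compound 2 to compound 4 (0.16 log units; within the scatter). Compound 4 is estimated at 2.5 mg/kg, within a range from 0.8 mg/kg to 6 mg/kg.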

Compound 4, dose for half-maximal effect: 7.15 mg/kg
Compound 4: middle estimate off by 2.9-fold (0.46 log units), on the low side, outside the stated range (above it).
By their numbers in this assay, from the lowest: compound 3; then compound 2; then compound 4.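

Replacing the 2,3-dihydro-1H-inden-2-yl group with the isomeric group carrying a four-membered non-aromatic ring gives a 4.1-fold higher number from compound 2 to compound 4 (0.62 log units; beyond the scatter) in this assay, so the response at this saturated chain carbon depends on how the same heavy atoms are joined, not only on which atoms are present. Among the compounds shown here, this is the first single-place step, and it runs toward more compound being needed for the effect. Compound 1 remains a limit rather than a number, so it cannot be placed in the order of the other compounds: the limit of > 2.5 mg/kg in this assay, at which 1 of the 4 values shown sits.

Nothing shown gives a reason for this step, and these compounds cannot separate the change in ring size from the rearrangement of the chain. Going by these compounds, it also remains open how this assay would respond to a longer chain on the 2,3-dihydro-1H-inden-2-yl group, or to an amine or a hydroxyl group on the saturated chain, and whether either would keep the number of compound 2 or move it further.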